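A few compounds are considered here, and "the series" means these few. Any claim that something is new, unique, unknown or untested is made for them only; others in the source may bear on it.

Values in an ADME assay on microsomes from liver (Mus musculus) for metabolic stability, read by mass spectrometry, using NADPH, tested at 1.5 uM; on this read-out higher numbers stand for a longer-lived compound and lower numbers for a shorter-lived compound:

- Compound 1 `O=C(Nc1ccc2sc(-c3cccc(F)c3)nc2c1)N1CCCCC1` gives 0.183 h
- Compound 2 `O=C(Nc1ccc2sc(-c3ccc(F)c(F)c3)nc2c1)N1CCCC1` gives 0.233 h
- Compound 3 `O=C(Nc1ccc2sc(-c3ccccc3)nc2c1)N1CCCC1` gives 0.3 h
- Compound 4 `O=C(Nc1ccc2sc(-c3cccc(F)c3)nc2c1)N1CCCC1` has not been measured yet

In this assay compound 3 gives 0.3 h, which lies within the usual scatter of both compound 1 and compound 2. The three numbers therefore do not separate these compounds.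

The next structure, compound 4, is made by a single change: fluoro in place of hydrogen on an aromatic carbon. The closest measured evidence is a 1.3-fold higher number from compound 2 to compound 3 (0.11 log units; within the scatter), in which phenyl takes the place of 3,4-difluorophenyl. That step also concerns fluoro on this ring, and it stays within the scatter. Compound 4 carries the same 3-fluorophenyl group as compound 1, which gives 0.183 h, but it differs from compound 4 elsewhere, so it offers only loose support.

No change beyond the scatter is therefore expected, and the expected step is small: a 1.2-fold lower number from compound 3 to compound 4 (0.08 log units; within the scatter). For compound 4 the estimated half-life is 0.25 h, with an expected range from 0.15 h to 0.42 h.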

Compound 4, half-life: 0.2 h
Compound 4: the middle estimate sits 1.3-fold (0.10 log units) above what was measured, within the range that was stated.
By their numbers in this assay, from the lowest: compounds 1, 4, 2 and 3 (each within the scatter of the next).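

Compound 4 allows the change from phenyl to 3-fluorophenyl to be read on its own, and in this assay it gives a step that stays within the scatter (a 1.5-fold lower number from compound 3 to compound 4 (0.18 log units; within the scatter)). Two further comparisons also stay within the scatter: hydrogen in place of the second fluoro (a 1.2-fold lower number from compound 2 to compound 4 (0.07 log units; within the scatter)) and pyrrolidin-1-yl in place of piperidin-1-yl on the carbonyl carbon (a 1.1-fold higher number from compound 1 to compound 4 (0.04 log units; within the scatter)), so neither change separates these compounds. No supporting measurement is available to explain these half-lives.

From the compounds shown here alone, on the aromatic ring, these compounds carry only hydrogen or fluoro, so the effect of a methoxy group or a nitrile at this place remains open. Going by these compounds, whether an open-chain amine such as dimethylamino on the carbonyl carbon would fall within the same scatter also remains open.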